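Working notes: the step from compound 3 to compound 4

The source may hold more compounds than are shown below. What is called first, only, known or untested is meant among the compounds shown, and "the series" means these compounds.

Measured in a functional assay on HEK293 cells (Homo sapiens) for cytotoxicity; on this read-out lower numbers stand for higher toxicity in this test and higher numbers for lower toxicity in this test:
- compound 1 `COc1ccc([C@H]2CC(=O)N(c3cccc(O)c3)C2)cc1OC1CCCC1` gives > 10000 nM (a limit)
- compound 2 `COc1ccc([C@H]2CC(=O)N(c3cccc(NC(=O)C(C)=O)c3)C2)cc1OC1CCCC1` gives > 10000 nM (a limit)
- compound 3 `COc1ccc(OC)c(S(=O)(=O)Nc2cccc(N3C[C@@H](c4ccc(OC)c(OC5CCCC5)c4)CC3=O)c2)c1` gives 7590 nM (a number)

Within the data shown here, compound 3 holds the only true number on this read-out (7590 nM) and is therefore the sole numerical anchor. Compound 1 and compound 2 are each reported only as a limit, as this line records: the limit of > 10000 nM in this assay, at which 2 of the 3 values shown sit.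

Compound 4 `COc1ccc([C@H]2CC(=O)N(c3cccc(NS(=O)(=O)c4cccc(Cl)c4)c3)C2)cc1OC1CCCC1` carries 3-chlorophenyl in place of 2,5-dimethoxyphenyl on a sulfonyl sulfur. Among the measured compounds shown here, the only measured step is a step that the two limits leave unreadable from compound 1 to compound 2 and it cannot be read for size. It also involves no sulfonyl sulfur, so it offers no guide to this change. For the measured compounds named here, no measured step covers a swap on the sulfonyl sulfur, and no direction can be argued from the data.

In this assay the expectation therefore stays at the value of compound 3 (7590 nM), with no shift beyond the scatter. The expected change is a 1.1-fold lower number from compound 3 to compound 4 (0.04 log units; within the scatter) with no direction favoured. A report of compound 4 as a limit alone would fit this expectation too. For compound 4 the estimated value is 7000 nM with an expected range from 3000 nM to 14000 nM.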

Compound 4, half-maximal cytotoxic concentration: > 10000 nM
Compound 4: no number, only a limit; the forecaster's own chance of this, stated with the estimate: 40%; at least 1.4-fold (0.15 log units) between middle value and limit.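

In this assay, among these compounds, 3-chlorophenyl in place of 2,5-dimethoxyphenyl on a sulfonyl sulfur gives the first step that has any readable size (an at least 1.3-fold higher number from compound 3 to compound 4 (0.11 log units; that floor lies within the scatter)), although compound 4 is reported only as a limit and the step therefore has a floor and no upper bound. A sulfonamide nitrogen carrying a sulfonyl group does not by itself give a number on this read-out, since compound 3 and compound 4 share that link and only compound 3 has a true value, so the swap of the aryl group on the sulfonyl sulfur remains a change with no measured size. The steps from compound 1 and compound 2 to compound 4 cannot be read, and the series now sits largely at one limit: the limit of > 10000 nM in this assay, at which 3 of the 4 values shown sit.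

Going by these compounds, whether a single methoxy group on the phenyl ring would keep the value of compound 3 or move it to the limit remains open. Also open, on these data alone, is how a methyl group, an aminophenyl group or a carboxylic acid on the aryl ring would read on the sulfonyl sulfur in this assay.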